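A few compounds are considered here, and "the series" means these few. Any claim that something is new, unique, unknown or untested is made for them only; others in the source may bear on it.

Working notes on the series. Among the measured compounds shown here, compound 1 `O=C(Nc1ccc(Oc2ncnc3[nH]ncc23)cc1)Nc1ccc(C(F)(F)F)cc1` in an assay on isolated protein for inhibition of vascular endothelial growth factor receptor 2 (Danio rerio), read by fluorescence and microscopy, with a stated time of 33 h (on this read-out higher numbers stand for weaker inhibition and lower numbers for stronger inhibition), gives 1200 nM and is, of the two values shown, the only outright number. Compound 2 `Cn1ncc2c(Oc3ccc(NC(=O)Nc4ccc(C(F)(F)F)cc4)cc3)ncnc21` gives > 100000 nM, which is a limit of the assay and not a number. Compound 2 therefore sits at the limit of > 100000 nM in this assay, at which 1 of the 2 values shown sits. For the measured compounds named here, the single measured step, an at least 83-fold higher number from compound 1 to compound 2 (1.92 log units; beyond the scatter), concerns a methyl in place of hydrogen on an aromatic nitrogen of the shared core.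

Compound 3 `CC(C)c1cccc(NC(=O)Nc2ccc(Oc3ncnc4[nH]ncc34)cc2)c1` departs from compound 1 at a different place: 3-isopropylphenyl in place of 4-(trifluoromethyl)phenyl on an amide-type nitrogen. Going by the values given here, no measured step touches the group on the amide-type nitrogen, so the step from compound 1 to compound 2 offers no guide to the size or direction of this change, and nothing else among the values shown does either. Among the compounds with values here, with no step of the same kind to lean on, the expectation in this assay is for a change of modest size in either direction, and the estimate carries a wide range. For compound 3 the expected step is a 1.7-fold higher number from compound 1 to compound 3 (0.22 log units; within the scatter). The estimate for compound 3 is 2000 nM, with a range from 500 nM to 8000 nM.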

Compound 3, half-maximal inhibitory concentration: 7730 nM
For compound 3 the middle estimate is 3.9-fold (0.59 log units) below the measured one, and the stated range covers the measured number.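

The group on the amide-type nitrogen is a second place where the number moves in this assay: 3-isopropylphenyl in place of 4-(trifluoromethyl)phenyl gives a 6.4-fold higher number from compound 1 to compound 3 (0.81 log units; beyond the scatter). Compound 3 keeps an outright number, so in this one example the change weakens inhibition without reaching a limit of the assay, and the group on this nitrogen is shown to matter beyond the scatter. No measured property shown accounts for this step.

The two groups differ in more than one feature, so the compounds shown do not separate the loss of trifluoromethyl from the arrival of isopropyl; plain phenyl, 4-isopropylphenyl or 3-(trifluoromethyl)phenyl on the same nitrogen would begin to do that. Also open, as far as these compounds go, is whether a phenyl carrying an amine or a carboxylic acid would be tolerated at this place, and whether methyl on the aromatic nitrogen of the shared core has the same effect when 3-isopropylphenyl is present.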